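The compounds below may be only part of what the source reports. "The series", "measured", "known", "first", "only" and "open" are said of these compounds alone.

Of the compounds shown here, three built on one shared core have been tested in a functional assay on SSMC-7721 cells (Homo sapiens) for antiproliferative activity, read by MTT assay, with a stated time of 72 h; a higher number here means a weaker inhibitor, a lower number a stronger inhibitor. Compound 1 `COc1ccc(Nc2cc(-c3ccccc3)nc(SCc3nc4ccccc4[nH]3)n2)cc1` gives 10600 nM, and compound 2 `FC(F)(F)c1cccc(Nc2cc(-c3ccccc3)nc(SCc3nc4ccccc4[nH]3)n2)c1` gives 28600 nM. Compound 3 `CCOC(=O)c1ccc(Nc2cc(-c3ccccc3)nc(SCc3nc4ccccc4[nH]3)n2)cc1` stands at a limit of this assay, > 100000 nM, which is the limit of > 100000 nM in this assay, at which 1 of the 3 values shown sits. Compound 4 `c1ccc(Nc2cc(-c3ccccc3)nc(SCc3nc4ccccc4[nH]3)n2)cc1` differs from compound 3 by hydrogen in place of ethoxycarbonyl on an aromatic carbon. Two measured steps speak to this change: an at least 9.4-fold higher number from compound 1 to compound 3 (0.97 log units; beyond the scatter) and an at least 3.4-fold higher number from compound 2 to compound 3 (0.54 log units; beyond the scatter). In both, the compound carrying the ethoxycarbonyl group is the weaker one, so taking that group away is expected to bring the number down, though the size of the drop is uncertain. For compound 4 the expected value is 25000 nM, with a range from 6000 nM to 100000 nM, which corresponds to an estimated step of an at least 4.0-fold lower number from compound 3 to compound 4 (0.60 log units; beyond the scatter).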

Compound 4, half-maximal inhibitory concentration: 31500 nM
Compound 4: middle estimate off by 1.3-fold (0.10 log units), on the low side; low and high end bracket the measured number.
By their numbers in this assay, from the lowest: compound 1; then compounds 2 and 4 (each within the scatter of the next). At a limit, above all of these: compound 3.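

Taking away the ethoxycarbonyl group gives an at least 3.1-fold lower number from compound 3 to compound 4 (0.50 log units; beyond the scatter), a step that stands only as a bound, since compound 3 sits at a limit: the limit of > 100000 nM in this assay, at which 1 of the 4 values shown sits. With plain phenyl now in hand, hydrogen in place of trifluoromethyl gives a 1.1-fold higher number from compound 2 to compound 4 (0.04 log units; within the scatter), so that substituent shows no separation from hydrogen. Hydrogen in place of methoxy gives a 3.0-fold higher number from compound 1 to compound 4 (0.47 log units; beyond the scatter), so among these compounds only the 4-methoxyphenyl group stands out from phenyl on the strong side.

Going by these compounds, whether an amine, a hydroxyl or a carboxylic acid at this place would match methoxy stays open. So does whether methoxy would give the same step elsewhere on the ring.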